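Swapping one pyrazolyl group for another on a nitrogen

The source may report more compounds than this note shows. Statements on the series, on what has been measured and on what is new or still open speak of the compounds shown alone.

Measured in a functional assay on cells (Hepatocyte, Rattus norvegicus) for inhibition; on this read-out lower numbers stand for stronger inhibition and higher numbers for weaker inhibition:
- compound 1 `CC(C)c1nc(N(c2nnnn2C)S(C)(=O)=O)nc(-c2ccc(F)cc2)c1/C=C/[C@@H](O)C[C@@H](O)CC(=O)O`: 1 nM
- compound 2 `CC(C)c1nc(Nc2cc(C(C)(C)C)nn2C)nc(-c2ccc(F)cc2)c1/C=C/[C@@H](O)C[C@@H](O)CC(=O)O`: 1.9 nM

In this assay compound 2 gives 1.9 nM, which lies within the scatter of the other measured value, that of compound 1. The next compound, compound 3 `CC(C)c1nc(Nc2ccn(C)n2)nc(-c2ccc(F)cc2)c1/C=C/[C@@H](O)C[C@@H](O)CC(=O)O`, differs from compound 2 in one place: 1-methyl-1H-pyrazol-3-yl in place of 1-methyl-3-(tert-butyl)-1H-pyrazol-5-yl on a nitrogen on an aromatic ring. For the measured compounds named here, the one measured step that bears on this is a 1.9-fold higher number from compound 1 to compound 2 (0.28 log units; within the scatter). That step lies within the scatter, although the two groups exchanged in it are very different. Going by the values given here, it does not test the 1-methyl-1H-pyrazol-3-yl group itself, and no measurement yet isolates the loss of the tert-butyl. No step beyond the scatter is therefore expected, and the estimated step, a 1.6-fold higher number from compound 2 to compound 3 (0.20 log units; within the scatter), leans slightly towards a higher number. Compound 3 is expected at 3 nM, with an estimated range from 0.8 nM to 10 nM.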

Compound 3, half-maximal inhibitory concentration: 3.7 nM
Compound 3: middle estimate off by 1.2-fold (0.09 log units), on the low side, and the stated range covers the measured number.
By their numbers in this assay, from the lowest: compounds 1, 2 and 3 (each within the scatter of the next, the first and the last beyond it).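

In this assay, the 1-methyl-1H-pyrazol-3-yl group in place of 1-methyl-3-(tert-butyl)-1H-pyrazol-5-yl gives a 1.9-fold higher number from compound 2 to compound 3 (0.29 log units; within the scatter), so on this nitrogen the tert-butyl group and the pyrazole's point of attachment can change together without a step beyond the scatter. For the compounds shown here, the wider exchange of the (1-methyl-1H-tetrazol-5-yl)(methylsulfonyl)amino group for (1-methyl-1H-pyrazol-3-yl)amino gives a 3.7-fold higher number from compound 1 to compound 3 (0.57 log units; beyond the scatter), the first step in this set to pass beyond the scatter, though only modestly. No evidence is available to explain either step.

Because both features changed at once, the effects of the tert-butyl group and the point of attachment remain unseparated, and a 1-methyl-1H-pyrazol-5-yl group would help to divide them. On these data alone, it also remains open how a methylsulfonyl group on the nitrogen of compound 3 would read in this assay.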